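Pyrazole enones: one methoxy removed from compound 2

The source may hold more compounds than are shown below. What is called first, only, known or untested is meant among the compounds shown, and "the series" means these compounds.

Compound 1 `COc1ccc(-c2cc(/C=C/C(=O)c3ccc(N)cc3)[nH]n2)cc1` gives 3220 nM in a functional assay on NCI-H23 cells (Homo sapiens) for inhibition, read by sulforhodamine B assay, with a stated time of 48 h; on this read-out lower numbers stand for stronger inhibition of growth and higher numbers for weaker inhibition of growth. Compound 2 `COc1cc(-c2cc(/C=C/C(=O)c3ccc(N)cc3)[nH]n2)cc(OC)c1OC` gives 2480 nM in this assay, and compound 3 `COc1ccc(C(=O)/C=C/c2cc(-c3cc(OC)c(OC)c(OC)c3)n[nH]2)cc1OC` gives 2150 nM. Among the compounds with values here, the only single-point step measured is a 1.2-fold lower number from compound 2 to compound 3 (0.06 log units; within the scatter). Compound 2 therefore sits second highest of the three numbers, with compound 3 nearest and compound 1 furthest; all three lie within the scatter of one another, so no order among them is established. Compound 4 `COc1ccc(-c2cc(/C=C/C(=O)c3ccc(N)cc3)[nH]n2)cc1OC` differs from compound 2 by hydrogen in place of methoxy on an aromatic carbon. Within the data shown here, no measured step matches this change: the step to compound 3 alters the carbonyl side of the molecule, and compounds 1 and 2 differ in several places at once, their numbers lying within the scatter of each other. With the three numbers spanning such a narrow band and the change being small, compound 4 is expected to stay within the scatter, with a 1.0-fold higher number from compound 2 to compound 4 (0.00 log units; within the scatter) the estimated step. For compound 4 the expected value is 2500 nM, with a range from 1200 nM to 5500 nM.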

Compound 4, concentration for 50% growth inhibition: 4210 nM
Compound 4: the middle estimate sits 1.7-fold (0.23 log units) below what was measured; low and high end bracket the measured number.
By their numbers in this assay, from the lowest: compounds 3, 2, 1 and 4 (each within the scatter of the next).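

In this assay, with the 4-aminophenyl on the carbonyl carbon unchanged, the methoxy pattern on the other aromatic ring can now be read from both directions: hydrogen in place of methoxy gives a 1.7-fold higher number from compound 2 to compound 4 (0.23 log units; within the scatter), and methoxy in place of hydrogen gives a 1.3-fold higher number from compound 1 to compound 4 (0.12 log units; within the scatter). Both steps lie within the scatter, so neither the methoxy lost from compound 2 nor the one added to compound 1 is shown to change growth inhibition on this read-out. No measurement is available that would explain where these numbers fall. As far as these compounds go, whether a different group on this aromatic carbon, such as a hydroxyl, a fluorine or a longer ethoxy chain, would give a step beyond the scatter remains open. Also open, from the compounds shown here alone, is whether the same change gives a similar step with the 3,4-dimethoxyphenyl on the carbonyl carbon, as in compound 3.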